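Swapping Benzothiophene for Benzofuran on a Shared Core

This account rests on a few compounds, and the source may have more. Where it says the series, first, only, none or still open, it means among the compounds named here.

Compound 1 `O=C1C=CC2(C=C1)OC(=O)C(I)=C2c1ccccc1`: 7510 nM
Compound 2 `O=C1C=CC2(C=C1)OC(=O)C(c1cc3ccccc3s1)=C2c1ccccc1`: 32900 nM

Of the compounds shown here, two built on one shared core have been measured in a functional assay on MDA-MB-231 cells (Homo sapiens) for antiproliferative activity, read by MTT assay, with a stated time of 48 h; a higher number here means a weaker inhibitor, a lower number a stronger inhibitor. For the measured compounds named here, compound 2 stands at the highest of the two numbers in this assay; its nearest neighbour is compound 1, and the single measured step, a 4.4-fold higher number from compound 1 to compound 2 (0.64 log units; beyond the scatter), records what followed when iodo gave way to the fused bicyclic group. Compound 3 `O=C1C=CC2(C=C1)OC(=O)C(c1cc3ccccc3o1)=C2c1ccccc1` differs from compound 2 by one exchange: 1-benzofuran-2-yl in place of 1-benzothiophen-2-yl on a double-bonded ring carbon. Going by the values given here, no measured step bears directly on this swap. Among the compounds with values here, the one step available, a 4.4-fold higher number from compound 1 to compound 2 (0.64 log units; beyond the scatter), concerns a different exchange and shows only that this position accepts a fused bicyclic group with a modest loss. With the two fused groups alike in their counted atoms and rings, compound 3 is expected to move little, and a 1.1-fold lower number from compound 2 to compound 3 (0.04 log units; within the scatter) is estimated to stay within the scatter. The estimate for compound 3 in this assay is 30000 nM, with a range from 10000 nM to 90000 nM.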

Compound 3, half-maximal inhibitory concentration: 21200 nM
Compound 3: the middle estimate sits 1.4-fold (0.15 log units) above what was measured; measured number inside the range.
By their numbers in this assay, from the lowest: compound 1; then compounds 3 and 2 (each within the scatter of the next).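

In this assay, exchanging 1-benzothiophen-2-yl for 1-benzofuran-2-yl, which changes only sulfur to oxygen in the counted atoms, leaves the result within the scatter (a 1.6-fold lower number from compound 2 to compound 3 (0.19 log units; within the scatter)), so the two fused groups cannot be told apart at this double-bonded ring carbon. Iodo in place of a fused group now has two comparisons, since the second fused group also gives a number beyond the scatter (a 2.8-fold higher number from compound 1 to compound 3 (0.45 log units; beyond the scatter)), and the loss is thus not confined to 1-benzothiophen-2-yl. No measured evidence bears on what lies behind either step.

The compounds shown leave open whether a smaller group on this carbon, such as a bromo or a methyl, would match iodo. They also do not show how an amine or a carboxylic acid on a fused group would fare.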